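Ethyl to Methoxy in Compound 3: An Expected Half-Life

The source may hold more compounds than are shown below. What is called first, only, known or untested is meant among the compounds shown, and "the series" means these compounds.

Of the compounds shown here, two sharing one core have been measured so far. In an in vitro ADME assay on microsomes (Homo sapiens) for metabolic stability (on this read-out higher numbers stand for a longer-lived compound and lower numbers for a shorter-lived compound), compound 1 `CCc1nc(-c2ccc(OC)cc2OC(F)(F)F)c(CC)nc1NC(CC)CC` gives 0.267 h, and compound 2 `CCc1nc(-c2ccc(OC)cc2C(F)(F)F)c(CC)nc1NC(CC)CC` gives 0.2 h. These two values lie within the scatter of each other, so compound 2 stands level with compound 1 on the present numbers.

Compound 3 `CCc1nc(NC(CC)CC)c(OC)nc1-c1ccc(OC)cc1C(F)(F)F` departs from compound 2 by one change: methoxy in place of ethyl on an aromatic carbon, next to the ring nitrogen and ortho to a (pentan-3-yl)amino group (methoxy in place of ethyl on an aromatic carbon).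

Within the data shown here, the only measured step, a 1.3-fold lower number from compound 1 to compound 2 (0.13 log units; within the scatter), is small and within the scatter. It concerns trifluoromethyl in place of trifluoromethoxy, not the ethyl group, so it bears on the new change only indirectly. Among the measured compounds shown here, no measured pair exchanges ethyl for methoxy, and the data therefore favour neither direction. No shift beyond the scatter is expected in this assay. The expected step is a 1.1-fold higher number from compound 2 to compound 3 (0.04 log units; within the scatter). For compound 3 the estimated half-life is 0.22 h, with an expected range from 0.1 h to 0.5 h.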

Compound 3, half-life: 2 h
The estimate for compound 3 lay 9.1-fold (0.96 log units) below the measured number, and the stated range ends below it.
By their numbers in this assay, from the lowest: compounds 2 and 1 (each within the scatter of the next); then compound 3.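

In this assay the aromatic carbon next to the ring nitrogen and ortho to a (pentan-3-yl)amino group turns out to be a place where a single exchange matters: methoxy in place of ethyl, a swap that leaves the heavy-atom count of the group unchanged, gives a 10-fold higher number from compound 2 to compound 3 (1.00 log units; beyond the scatter) and so moves the number beyond the scatter. Among these compounds, the earlier compounds could not show this, since both carry ethyl here and their only step (a 1.3-fold lower number from compound 1 to compound 2 (0.13 log units; within the scatter)) concerns trifluoromethoxy and trifluoromethyl at another place and stays within the scatter. Nothing available here accounts for the size of this step, so it stands as an observation without an explanation.

The compounds shown leave open whether the step belongs to methoxy in particular or would also appear with other groups at this carbon, such as ethoxy, a hydroxyl group, a chlorine atom or a small amine. They also leave open whether the same exchange would give a similar step at the ethyl group para to this position, or in the presence of trifluoromethoxy in place of trifluoromethyl.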